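This account rests on a few compounds, and the source may have more. Where it says the series, first, only, none or still open, it means among the compounds named here.

Measured compounds in an assay on HEK293 cells for inhibition of Leucine-rich repeat serine/threonine-protein kinase 2 (Homo sapiens), with a stated time of 48 h; a higher number here means a weaker inhibitor, a lower number a stronger inhibitor:

- compound 1, `Cc1c(Nc2nc(N)c3c(C#N)c(N4CCC[C@H]4C)n(C)c3n2)cnn1[C@H]1CCOC1`: 140 nM
- compound 2, `Cc1nn(C2CCOC2)cc1Nc1nc(N)c2c(C#N)c(N3CCC[C@H]3C)n(C)c2n1`: 140 nM; 260 nM (2 entries)
- compound 3, `Cc1nn(CC(C)(C)O)cc1Nc1nc(N)c2c(C#N)c(N3CCC[C@H]3C)n(C)c2n1`: 280 nM

All three share one core and differ only in the group carried on an aromatic nitrogen of the five-membered ring. In this assay compound 1 gives 140 nM, and compound 3 gives 280 nM; these two numbers lie within the scatter of each other, so neither can be called the stronger inhibitor. Compound 2 has been measured more than once, and the several entries of compound 2 in this assay, 140 nM; 260 nM (2 entries) shows how far repeated runs of the same compound can drift.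

Compound 4, `Cc1c(Nc2nc(N)c3c(C#N)c(N4CCC[C@H]4C)n(C)c3n2)cnn1CC(C)(C)O`, is not yet measured. It differs from compound 1 by 2-hydroxy-2-methylpropyl in place of oxolan-3-yl on an aromatic nitrogen. Compound 3 already carries the 2-hydroxy-2-methylpropyl group, and its number sits close to those of compound 1 and compound 2, so no step beyond the scatter is expected in this assay for this change. Compound 4 is therefore estimated at 240 nM, with a likely range from 110 nM to 550 nM. The step from compound 1 to compound 4 is expected to be a 1.7-fold higher number from compound 1 to compound 4 (0.23 log units; within the scatter), a slight weakening that stays within the scatter.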

Compound 4, half-maximal inhibitory concentration: 280 nM
Estimate against measurement, compound 4: 1.2-fold (0.07 log units) below, and the stated range covers the measured number.
By their numbers in this assay, from the lowest: compounds 1, 3 and 4 (each within the scatter of the next).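

Among these compounds, replacing oxolan-3-yl with 2-hydroxy-2-methylpropyl on an aromatic nitrogen gives a 2.0-fold higher number from compound 1 to compound 4 (0.30 log units; within the scatter) in this assay and so offers the one direct reading of this change on the core of compound 1. The swap gives up a ring and a defined stereocentre and brings in a hydrogen-bond donor, yet the step stays within the scatter, so this position tolerates both groups as far as this assay can tell. Repeated runs of a single compound spread just as widely: the several entries of compound 2 in this assay, 140 nM; 260 nM (2 entries)

As far as these compounds go, whether an amine, a carboxylic acid or a longer chain on this nitrogen would produce a step beyond the scatter remains open. The compounds shown also cannot say how this change would read in any other assay.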